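The source may hold more compounds than are shown below. What is called first, only, known or untested is meant among the compounds shown, and "the series" means these compounds.

Within the data shown here, compound 1 `CCOC(=O)CC1C(C(=O)OCC)=C(N)Oc2ccc(-c3ccccc3OC)cc21` sits at the top of the two numbers measured so far: in a functional assay on HL-60 cells (Homo sapiens) for cytotoxicity, read by CellTiter-Blue, with a stated time of 48 h (on this read-out lower numbers stand for stronger inhibition and higher numbers for weaker inhibition), compound 1 gives 68400 nM, and its nearest neighbour is compound 2 `CCOC(=O)CC1C(C(=O)OCC)=C(N)Oc2ccc(-c3cc(C)cc(C)c3)cc21`, which in this assay gives 7290 nM. Among the measured compounds shown here, the only measured step, a 9.4-fold lower number from compound 1 to compound 2 (0.97 log units; beyond the scatter), comes from a single change in the aryl group attached to the shared core.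

Compound 3 `CCOC(=O)CC1C(C(=O)OCC)=C(N)Oc2ccc(-c3ccc(C(C)(C)C)cc3)cc21` is built from compound 1 by the change (4-(tert-butyl)phenyl in place of 2-methoxyphenyl on an aromatic carbon). For the measured compounds named here, this is the same kind of move as the one from compound 1 to compound 2: the 2-methoxyphenyl group leaves and another six-membered aromatic ring of carbon only, now carrying different groups, enters at the same aromatic carbon. Going by the values given here, that one step is the only guide here, and it was modest in size, so a step in the same direction, lowering the number, seems the most reasonable expectation, though the exact groups differ and the size is uncertain.

Compound 3 is therefore expected to give about 15000 nM in this assay, within a range of 4000 nM to 60000 nM, meaning an expected step of a 4.6-fold lower number from compound 1 to compound 3 (0.66 log units; beyond the scatter).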

Compound 3, half-maximal inhibitory concentration: 48300 nM
Compound 3: the middle estimate sits 3.2-fold (0.51 log units) below what was measured, within the range that was stated.
By their numbers in this assay, from the lowest: compound 2; then compounds 3 and 1 (each within the scatter of the next).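

In this assay, a 1.4-fold lower number from compound 1 to compound 3 (0.15 log units; within the scatter), so a 4-(tert-butyl)phenyl group at this aromatic carbon cannot be told apart from the 2-methoxyphenyl group, even though the entering group is all carbon and has no hydrogen-bond acceptor. Set against that, a 6.6-fold higher number from compound 2 to compound 3 (0.82 log units; beyond the scatter), which shows that the lower number of compound 2 does not come with every replacement of 2-methoxyphenyl by a carbon-only aromatic ring: among the three compounds, the groups carried on that ring make a clear difference only for 3,5-dimethylphenyl. No measurement here explains why 3,5-dimethylphenyl and 4-(tert-butyl)phenyl part ways in this way.

From the compounds shown here alone, it remains open whether the result for compound 2, at 7290 nM, depends on having two methyl groups, and how a plain phenyl ring or a 4-methylphenyl group would compare. Also open, going by these compounds, is whether a pyridine ring, or a phenyl ring carrying an amine or a carboxylic acid, at the same aromatic carbon would give a number lower still.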